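The compounds below may be only part of what the source reports. "The series", "measured", "known", "first", "only" and "open" are said of these compounds alone.

Three compounds sharing a core were examined in an assay on isolated protein for displacement of a labelled ligand from metabotropic glutamate receptor 5 (Homo sapiens), with a stated time of 60 min, tested at 1 uM; on this read-out lower numbers stand for less inhibition and higher numbers for more inhibition at the one concentration tested (going by the name of the read-out). Compound 2 `COc1ccc2ncc(S(=O)(=O)c3cc(F)cc(F)c3)c(N3CCC(C)CC3)c2c1` gives 30%. Compound 1 `COc1ccc2ncc(S(=O)(=O)c3cccc(C#N)c3)c(N3CCC(C)CC3)c2c1` gives 90%, and compound 3 `CC1CCN(c2c(S(=O)(=O)c3cc(F)cc(F)c3)cnc3ccc(Cl)cc23)CC1` gives 93%, so that compound 3 and compound 1 lie within the scatter of each other. Two changes separate compound 2 from the other two. The first is 3-cyanophenyl in place of 3,5-difluorophenyl on a sulfonyl sulfur, which made a step of a number 60 percentage points higher from compound 2 to compound 1 (beyond the scatter). The second, the difference between the two cores, is chloro in place of methoxy on an aromatic carbon, which made a step of a number 63 percentage points higher from compound 2 to compound 3 (beyond the scatter).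

Compound 4 `CC1CCN(c2c(S(=O)(=O)c3cccc(C#N)c3)cnc3ccc(Cl)cc23)CC1` remains to be measured. It differs from compound 3 by 3-cyanophenyl in place of 3,5-difluorophenyl on a sulfonyl sulfur, the same change as that from compound 2 to compound 1, here made on the core of compound 3. Because compound 3 already gives 93%, little room is left on this read-out. For compound 4 the expected step is therefore a number 2 percentage points higher from compound 3 to compound 4 (within the scatter), far smaller than the earlier one. Compound 4 is estimated at 95%, most likely falling between 85% and 100%.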

Compound 4, a percentage reported as inhibition, at one concentration (the size of the read-out at that concentration, not a potency): 90%
Estimate against measurement, compound 4: 5 percentage points above, and the stated range covers the measured number.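

In this assay, 3-cyanophenyl in place of 3,5-difluorophenyl on the chloro core made a step of a number 3 percentage points lower from compound 3 to compound 4 (within the scatter), far from its size on the methoxy core: the same change on two cores in this assay, a number 60 percentage points higher (beyond the scatter) from compound 2 to compound 1 and a number 3 percentage points lower (within the scatter) from compound 3 to compound 4, 63 percentage points apart, beyond the scatter of two such steps Chloro in place of methoxy, made with 3-cyanophenyl on the sulfonyl sulfur, made a step of no change at the digits printed from compound 1 to compound 4 (within the scatter), and it too failed to repeat its earlier size: the same change on two cores in this assay, a number 63 percentage points higher (beyond the scatter) from compound 2 to compound 3 and no change at the digits printed (within the scatter) from compound 1 to compound 4, 63 percentage points apart, beyond the scatter of two such steps Neither change therefore carries over from one core to the other at the size first seen, but this does not show that either group has stopped mattering, as compound 1, compound 3 and compound 4 all sit near the top of a read-out taken at one concentration, where it cannot separate them.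

From the compounds shown here alone, whether these three compounds differ in potency stays open. So does whether the same dependence holds for other groups, such as bromo or trifluoromethyl on the aromatic carbon in place of chloro, or a pyridyl on the sulfonyl sulfur.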